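This account rests on a few compounds, and the source may have more. Where it says the series, first, only, none or still open, it means among the compounds named here.

Measured in a functional assay on DU-145 cells (Homo sapiens) for cytotoxicity, read by MTT assay; on this read-out lower numbers stand for stronger inhibition and higher numbers for weaker inhibition:
- compound 1 `CC(C)=CC[C@@H](OC[C@H](C)O)C1=CC(=O)c2c(O)ccc(O)c2C1=O` gives 24500 nM
- compound 2 `COCCO[C@H](CC=C(C)C)C1=CC(=O)c2c(O)ccc(O)c2C1=O` gives 43200 nM
- compound 3 `CCC(CO[C@H](CC=C(C)C)C1=CC(=O)c2c(O)ccc(O)c2C1=O)OC(C)=O` gives 25400 nM

Compound 3 cannot be separated from the other two compounds on these numbers: a 1.0-fold higher number from compound 1 to compound 3 (0.02 log units; within the scatter), and a 1.7-fold lower number from compound 2 to compound 3 (0.23 log units; within the scatter). The next compound, compound 4 `CCCC(C)(O)CC(=O)O[C@H](CC=C(C)C)C1=CC(=O)c2c(O)ccc(O)c2C1=O`, carries (2-hydroxy-2-methylpentyl)carbonyl in place of 2-acetoxybutyl on an oxygen on a saturated carbon.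

The three measured steps bear on this change only in part. Besides the two above, a 1.8-fold higher number from compound 1 to compound 2 (0.25 log units; within the scatter), so every chain exchange so far has stayed within the scatter. Yet in each of those compounds a saturated carbon sits on that oxygen, and none has a carbonyl there, as compound 4 does. The data therefore give no direct measure of this change, and no step beyond the scatter is expected, though with wide uncertainty in either direction. The expected change is a 1.4-fold lower number from compound 3 to compound 4 (0.15 log units; within the scatter). For compound 4 the estimated value is 18000 nM, with an expected range from 5000 nM to 45000 nM.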

Compound 4, half-maximal inhibitory concentration: 75000 nM
For compound 4 the middle estimate is 4.2-fold (0.62 log units) below the measured one, outside the stated range (above it).
By their numbers in this assay, from the lowest: compounds 1, 3, 2 and 4 (each within the scatter of the next, the first and the last beyond it).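

Within the data shown here, with compound 4, a carbonyl-bearing group stands on this oxygen for the first time, and in this assay it brings the first steps beyond the scatter at this position, both toward weaker inhibition (a 3.0-fold higher number from compound 3 to compound 4 (0.47 log units; beyond the scatter); a 3.1-fold higher number from compound 1 to compound 4 (0.49 log units; beyond the scatter)). Among the chains with a saturated carbon on that oxygen, every exchange had stayed within the scatter, so this change reaches further than any of them, although compound 2 goes against a clean separation (a 1.7-fold higher number from compound 2 to compound 4 (0.24 log units; within the scatter)). Nothing measured here offers an explanation for this shift.

The compounds shown leave open whether the step belongs to the carbonyl itself or to the branched hydroxylated chain it carries. A plain hexanoyl group on the same oxygen would separate the two.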